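The source may hold more compounds than are shown below. What is called first, only, known or untested is meant among the compounds shown, and "the series" means these compounds.

Measured compounds in a functional assay on Huh-7 cells (Homo sapiens) for cytotoxicity, read by MTT assay, with a stated time of 3 days; on this read-out lower numbers stand for higher toxicity in this test and higher numbers for lower toxicity in this test:
- compound 1 `O=c1ccn(Cc2ncnc3c2ncn3[C@@H]2O[C@H](CO)[C@@H](O)[C@H]2O)cc1`: > 100000 nM
- compound 2 `O=c1ccccn1Cc1ncnc2c1ncn2[C@@H]1O[C@H](CO)[C@@H](O)[C@H]1O`: > 100000 nM

Compound 1 stands only at a limit of the assay in this assay, with > 100000 nM being a limit and not a number. Compound 2 likewise returns only a limit, > 100000 nM. Within the data shown here, the one measured step, a step that the two limits leave unreadable from compound 1 to compound 2, is therefore unreadable in size and direction: both ends of it sit at the limit of > 100000 nM in this assay, at which 2 of the 2 values shown sit, and the change of one six-membered aromatic ring with one hetero atom for another gave no readable signal.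

Compound 3 `O=C(O)CSCc1ncnc2c1ncn2[C@@H]1O[C@H](CO)[C@@H](O)[C@H]1O` is not yet measured. It differs from compound 1 by a group of 5 heavy atoms (2 carbon, 2 oxygen, 1 sulfur; no ring) in place of a group of 7 heavy atoms (5 carbon, 1 nitrogen, 1 oxygen; one six-membered aromatic ring with 1 hetero atom), on a saturated chain carbon bound to an aromatic carbon. Among the measured compounds shown here, no measured step bears directly on this change; the only comparison available, from compound 1 to compound 2, is unreadable, and neither measured compound shows cytotoxicity within the tested range. On that basis compound 3 is expected to behave the same way, with the step that the limit leaves unreadable from compound 1 to compound 3 expected to be none beyond the scatter and most likely to be reported again as a limit. The estimate for compound 3 in this assay is 150000 nM, with an expected range from 50000 nM to 500000 nM.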

Compound 3, half-maximal cytotoxic concentration: > 100000 nM
Compound 3: only a limit was reported (the forecaster's own chance of this, stated with the estimate: 85%); the middle value lies beyond the limit too.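

The steps from compound 1 and compound 2 to compound 3 cannot be read in this assay, as all three compounds return a limit and not a number: the limit of > 100000 nM in this assay, at which 3 of the 3 values shown sit.

The compounds shown leave open whether any group on this saturated chain carbon gives a measurable half-maximal cytotoxic concentration, and how far the (carboxymethyl)sulfanyl compound truly differs from the other two.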